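Fluoro for Methoxy on Two Cores in Cytotoxicity

The source may hold more compounds than are shown below. What is called first, only, known or untested is meant among the compounds shown, and "the series" means these compounds.

Compound 1 `COc1ccc(/C=C/C(=O)c2cc(NC(C)=O)ccc2O)cc1` and compound 2 `CC(=O)Nc1ccc(O)c(C(=O)/C=C/c2ccc(F)cc2)c1` share one core and differ in a single place, the change being (fluoro in place of methoxy on an aromatic carbon). In an ADME assay on THP-1 cells (Homo sapiens) for cytotoxicity, read by flow cytometry and propidium iodide staining, with a stated time of 72 h (a higher number here means a weaker inhibitor, a lower number a stronger inhibitor), compound 1 gives 59200 nM, and compound 2 gives 68800 nM, so the step of a 1.2-fold higher number from compound 1 to compound 2 (0.07 log units; within the scatter) is no more than the usual scatter. Compound 3 `COc1ccccc1-c1cc(=O)c2cc(NC(C)=O)ccc2o1` is built on a different core; how the two cores differ is not broken down here. In this assay compound 3 gives 50000 nM, a number that lies within the scatter of both compound 1 and compound 2. Compound 4 `CC(=O)Nc1ccc2oc(-c3ccccc3F)cc(=O)c2c1` differs from compound 3 by fluoro in place of methoxy on an aromatic carbon. Among the measured compounds shown here, this is the same kind of change as the one from compound 1 to compound 2, but not the same: there the fluoro sits para to a large group, here ortho to a large group. Because the earlier step of a 1.2-fold higher number from compound 1 to compound 2 (0.07 log units; within the scatter) stayed within the scatter, the step of a 1.1-fold higher number from compound 3 to compound 4 (0.04 log units; within the scatter) is expected to be similarly small. Compound 4 is therefore estimated at 55000 nM, with a likely range from 30000 nM to 100000 nM.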

Compound 4, half-maximal inhibitory concentration: > 125000 nM
Compound 4: no number, only a limit; the forecaster's own chance of this, stated with the estimate: 15%; middle value at least 2.2-fold (0.35 log units) from the limit.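

In this assay compound 4 gives > 125000 nM, which is a limit of the assay and not a number. On the second core, fluoro in place of methoxy gives an at least 2.5-fold higher number from compound 3 to compound 4 (0.39 log units; beyond the scatter), so a step that stayed small on the core of compound 1 was no safe guide to the size of the same change on the core of compound 3. This does not show that the change truly acts differently on the two cores, and the full size of the second step remains unknown: the same change on two cores in this assay, a 1.2-fold higher number (0.07 log units; within the scatter) from compound 1 to compound 2 and an at least 2.5-fold higher number (0.39 log units; beyond the scatter) from compound 3 to compound 4; the limit leaves it open whether they differ

The compounds shown set only methoxy against fluoro, so they leave open how a chloro group, a nitrile or an amine would read at the same place on either core. They also leave open whether fluoro or methoxy at another place on the same aromatic ring would give a step like either of these two.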